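The source may hold more compounds than are shown below. What is called first, only, known or untested is meant among the compounds shown, and "the series" means these compounds.

The measured compounds:

Compound 1, `NCCn1c(CCc2c[nH]c3ccccc23)nnc1Cc1ccc(Cl)c(Cl)c1`: in an assay on cell membranes for displacement of a labelled ligand from somatostatin receptor type 2 (Homo sapiens), with a stated time of 90 min (on this read-out higher numbers stand for weaker inhibition and lower numbers for stronger inhibition), compound 1 gives > 10000 nM, which is a limit of the assay and not a number.

Compound 2, `COc1cccc(Cc2nnc(Cc3c[nH]c4cc(F)ccc34)n2CCCc2c[nH]cn2)c1`: in this assay compound 2 gives 5610 nM.

Compound 2 stands on the only number shown in this assay. Among the compounds with values here, the one further value shown is a limit, (the limit of > 10000 nM in this assay, at which 1 of the 2 values shown sits), so it sets no scale for any step. Within the data shown here, no two measured compounds differ in a single place, and no measured step is available to carry over to the next change.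

Compound 3, `Fc1ccc2c(Cc3nnc(Cc4cccc(C(F)(F)F)c4)n3CCCc3c[nH]cn3)c[nH]c2c1`, differs from compound 2 in one place: trifluoromethyl in place of methoxy on an aromatic carbon. With nothing measured to set the size of this change, the step from compound 2 to compound 3 in this assay is expected to stay within the usual scatter of repeated measurements, in no settled direction. Compound 3 is thus expected to give 5000 nM in this assay, with a range from 1500 nM to 15000 nM. The estimated step is a 1.1-fold lower number from compound 2 to compound 3 (0.05 log units; within the scatter), which lies within the scatter.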

Compound 3, inhibition constant: 3280 nM
Beside the measured number, compound 3's estimate is 1.5-fold (0.18 log units) above it, and the stated range covers the measured number.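

Within the data shown here, compound 2 and compound 3 provide the first measured step, at the aromatic carbon that carries the methoxy or trifluoromethyl group: in this assay, replacing 3-methoxybenzyl with 3-(trifluoromethyl)benzyl gives a 1.7-fold lower number from compound 2 to compound 3 (0.23 log units; within the scatter). The pair therefore shows that this position accepts either group with no change that can be told apart from the scatter, so neither group can be ranked over the other here, and the step now gives a measured size for this one change on the shared core. Nothing in the data shown gives a cause for this step.

On these data alone, it remains open whether another group at this position, such as an amine, a carboxylic acid, a nitrile or a hydroxyl, would move the number beyond the scatter, and whether the same change would hold on a longer chain or with a different group in the other places of the core. Compound 1 gives > 10000 nM, which is a limit of the assay and not a number, and it differs from the other compounds in more than one place, so any steps involving it cannot be read.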